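From methoxycarbonyl to carbamoyl on the shared core

The source may report more compounds than this note shows. Statements on the series, on what has been measured and on what is new or still open speak of the compounds shown alone.

- compound 1 `COC(=O)c1cn2ccncc2n1`: > 34 nM
- compound 2 `CCOC(=O)Cc1cn2cc(Br)nc(Br)c2n1`: 21 nM
- compound 3 `Brc1cncc2nccn12`: 18 nM

In a functional assay on the whole organism for inhibition, with Cavia porcellus as the target (a higher number here means that more compound is needed for the effect, a lower number that less compound is needed), compound 1 gives > 34 nM, which is a limit of the assay and not a number. Compound 2 gives 21 nM and compound 3 gives 18 nM, two values close together. Compound 4 `NC(=O)c1cn2ccncc2n1` has amino in place of methoxy on a carbonyl carbon. Among the compounds with values here, no measured pair shows this change, and the only anchor is a limit. In this assay, a step no larger than the scatter is therefore expected, though with much uncertainty. The expected step is a step that the limit leaves unreadable from compound 1 to compound 4. Compound 4 is estimated at 45 nM, with an expected range of 14 nM to 150 nM.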

Compound 4, concentration for half-maximal effect: > 56 nM
Compound 4 gave a limit, no number (the forecaster's own chance of this, stated with the estimate: 35%); middle value at least 1.2-fold (0.09 log units) away from the limit.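

Compound 1 gives > 34 nM, a limit and not a number. Within the data shown here, compound 4 gives > 56 nM, also a limit, so no step between these two compounds can be read. Going by these compounds, whether amino in place of methoxy on a carbonyl carbon changes the value in this assay stays open.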